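From Compound 1 to Compound 4: a Dichlorophenyl Exchange

This account rests on a few compounds, and the source may have more. Where it says the series, first, only, none or still open, it means among the compounds named here.

Of the compounds shown here, three have so far been measured in a functional assay on U-87MG ATCC cells for inhibition, with U-87 MG (Homo sapiens) as the target, read by MTT assay, with a stated time of 72 h; on this read-out lower numbers stand for stronger inhibition and higher numbers for weaker inhibition. Compound 1 `CCc1ccc(C(Nc2ccccn2)c2ccc3cccnc3c2O)cc1` gives 9300 nM in this assay, the lower of the two numbers recorded; compound 2 `Oc1cc2c(cc1C(c1ccc(F)cc1)N1CCCCC1)CCC2` gives 13000 nM, and the gap between these two sits within the usual scatter, so neither can be set apart from the other. Compound 3 `Cc1ccnc(NC(c2ccc(F)cc2)c2ccc3cccnc3c2O)c1` yields only a limit of this assay, > 10000 nM. That limit is the limit of > 10000 nM in this assay, at which 1 of the 3 values shown sits.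

Compound 4 `Oc1c(C(Nc2ccccn2)c2c(Cl)cccc2Cl)ccc2cccnc12` has not yet been measured in this assay. It differs from compound 1 at a single place: 2,6-dichlorophenyl in place of 4-ethylphenyl on a saturated chain carbon bound to an aromatic carbon and a nitrogen on an aromatic ring. Within the data shown here, no pair of measured compounds differs in one place, so no measured step offers a guide to what this change should do. On this basis the step from compound 1 to compound 4 is expected to be no larger than the scatter, in either direction, a 1.0-fold lower number from compound 1 to compound 4 (0.01 log units; within the scatter). Compound 4 is therefore estimated at 9000 nM in this assay, with a range from 3000 nM to 30000 nM.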

Compound 4, half-maximal inhibitory concentration: 6900 nM
For compound 4 the middle estimate is 1.3-fold (0.12 log units) above the measured one, and the stated range covers the measured number.
By their numbers in this assay, from the lowest: compounds 4, 1 and 2 (each within the scatter of the next).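

At the saturated chain carbon bound to an aromatic carbon and a nitrogen on an aromatic ring, the exchange of 4-ethylphenyl for 2,6-dichlorophenyl gives a 1.3-fold lower number from compound 1 to compound 4 (0.13 log units; within the scatter) in this assay as the read-out. Among these compounds, this is the first step read between measured compounds that differ in one place, and it shows that these two groups, each of 8 heavy atoms and one six-membered aromatic ring of carbon only, cannot be told apart on this read-out. Nothing measured here accounts for this result.

The compounds shown leave open whether a different kind of group at this place, such as an amine, a carboxylic acid or a longer chain, would move the number beyond the scatter. As far as these compounds go, whether a phenyl ring carrying a single chlorine would behave like 2,6-dichlorophenyl also remains open.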